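The source may report more compounds than this note shows. Statements on the series, on what has been measured and on what is new or still open speak of the compounds shown alone.

Compound 3 `CC(=O)N1CCC(C(=O)N(CCCN2CCN(Cc3ccc(C(F)(F)F)cc3)CC2)c2ccc(C)c(Cl)c2)CC1` is tested in an ADME assay (Homo sapiens) for cytotoxicity (a higher number here means that more compound is tolerated, a lower number that less compound is tolerated), together with two close relatives. Compound 1 `CC(=O)N1CCC(C(=O)N(CCCN2CCN(Cc3cccnc3)CC2)c2ccc(C)c(Cl)c2)CC1` reaches only the limit of > 56700 nM in this assay, which is a limit and not a number. Compound 2 `CC(=O)N1CCC(C(=O)N(CCCN2CCN(Cc3ccc(Cl)cc3)CC2)c2ccc(C)c(Cl)c2)CC1` gives 37600 nM in this assay, and compound 3 gives 30500 nM. Among the two plain numbers compound 3 has the lower one, but the gap between them, a 1.2-fold lower number from compound 2 to compound 3 (0.09 log units; within the scatter), does not separate the two. Against compound 1 the steps are an at least 1.5-fold lower number from compound 1 to compound 2 (0.17 log units; that floor lies within the scatter) and an at least 1.8-fold lower number from compound 1 to compound 3 (0.26 log units; that floor lies within the scatter), both floors within the scatter, as the limit of > 56700 nM in this assay, at which 1 of the 3 values shown sits, sets them.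

Compound 4 `CC(=O)N1CCC(C(=O)N(CCCN2CCN(Cc3ccc(Cl)nc3)CC2)c2ccc(C)c(Cl)c2)CC1` has not yet been measured in this assay. It differs from compound 3 in one place: 6-chloropyridin-3-yl in place of 4-(trifluoromethyl)phenyl on a saturated chain carbon bound to an amine nitrogen in a ring. The step from pyridin-3-yl to 4-(trifluoromethyl)phenyl, an at least 1.8-fold lower number from compound 1 to compound 3 (0.26 log units; that floor lies within the scatter), and the swap of chloro for trifluoromethyl, a 1.2-fold lower number from compound 2 to compound 3 (0.09 log units; within the scatter), both bear on this change, and neither rises beyond the scatter. A step of about a 1.4-fold higher number from compound 3 to compound 4 (0.14 log units; within the scatter) is therefore expected for compound 4, which would leave it within the scatter of compound 3. In this assay compound 4 is estimated at 42000 nM, with a likely range from 20000 nM to 90000 nM.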

Compound 4, half-maximal cytotoxic concentration: > 53100 nM
Compound 4: a limit, no number; the forecaster's own chance of this, stated with the estimate: 30%; at least 1.2-fold (0.10 log units) between middle value and limit.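

At this position, on a saturated chain carbon bound to an amine nitrogen in a ring, a ring with one hetero atom can now be compared with carbon-only rings while a chloro group is kept, and this assay gives an at least 1.7-fold higher number from compound 3 to compound 4 (0.24 log units; that floor lies within the scatter) and an at least 1.4-fold higher number from compound 2 to compound 4 (0.14 log units; that floor lies within the scatter), so neither floor separates the compounds. Compound 4 ends at a limit and not at a number: the limit of > 53100 nM in this assay, at which 1 of the 4 values shown sits. Among the compounds shown, compound 1 and compound 4, both with a nitrogen in this ring, end at limits while compound 2 and compound 3, with carbon-only rings, give plain numbers, a pattern that none of these compounds goes against, although the step between the two limits cannot be read.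

From the compounds shown here alone, it remains open whether the ring nitrogen truly goes with a higher number in this assay, as the floors of the steps lie within the scatter and no exact number exists for compound 1 or compound 4. Also open, going by these compounds, is how a pyridine with a methoxy group, an amine or a carboxylic acid in place of the chloro group would read at this position.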